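Trading methoxy for methyl on a shared core

The compounds below may be only part of what the source reports. "The series", "measured", "known", "first", "only" and "open" are said of these compounds alone.

Compound 2 `COc1ccccc1-c1nc(N)nc(N)n1` gives 1% in a functional assay on the whole organism with Rattus norvegicus as the target, at a dose of 20 mg/kg by the intraperitoneal route; a higher number here means more inhibition at the dose given (going by the name of the read-out), a lower number less inhibition. Among the compounds with values here, that is the higher of the two numbers measured so far, but only by a margin that means nothing: compound 1 `CCOc1ccccc1-c1nc(N)nc(N)n1` gives -5% in this assay, and the step of a number 6 percentage points higher from compound 1 to compound 2 (within the scatter) lies within the usual scatter of such measurements, so the two compounds stand level, both close to no inhibition at this dose.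

Compound 3 `Cc1ccccc1-c1nc(N)nc(N)n1` differs from compound 2 by methyl in place of methoxy on an aromatic carbon. Within the data shown here, no measured step swaps an oxygen-bearing group for a methyl, so nothing bears on this change directly. Among the measured compounds shown here, the only step in hand, hydrogen in place of methyl on a saturated chain carbon bound to an oxygen on an aromatic ring, altered the same group at the same place and gave a number 6 percentage points higher from compound 1 to compound 2 (within the scatter), a change within the scatter. With both measured compounds near zero and no change that moved the read-out, there is no ground to expect a step beyond the scatter in either direction.

Compound 3 is therefore estimated to give 0%, with a range from -12% to 12%. The expected step is a number 1 percentage points lower from compound 2 to compound 3 (within the scatter), within the scatter.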

Compound 3, a percentage reported as inhibition, in the whole organism at one dose (the size of the read-out at that dose, not a potency) in the Rattus norvegicus assay: 28%
The estimate for compound 3 lay 28 percentage points below the measured number; measured number outside the range, above it.
By their numbers in the Rattus norvegicus assay, from the lowest: compounds 1 and 2 (each within the scatter of the next); then compound 3.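

At this place, on an aromatic carbon ortho to a group of 8 heavy atoms, the oxygen-linked chain had seemed not to matter, as shortening ethoxy to methoxy left the read-out within the scatter, but replacing the whole group does matter: in the Rattus norvegicus assay, methyl in place of methoxy gives a number 27 percentage points higher from compound 2 to compound 3 (beyond the scatter), and methyl in place of ethoxy gives a number 33 percentage points higher from compound 1 to compound 3 (beyond the scatter). In a physicochemical assay for lipophilicity (on this read-out higher numbers stand for higher lipophilicity and lower numbers for lower lipophilicity), compound 2 gives 0.58 and compound 3 gives 1.26. The gain in inhibition therefore comes with a measured rise in lipophilicity, which may contribute to it, although this single pair cannot show that it does: the measured partition coefficient of compound 2, 0.58, and of compound 3, 1.26, a number 0.68 log units higher (beyond the scatter)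

The compounds shown leave open whether the inhibition in the Rattus norvegicus assay follows lipophilicity or depends instead on the oxygen and hydrogen-bond acceptor that leave with methoxy. They also leave open whether a chlorine atom, an ethyl group or a plain hydrogen at this place would give more or less inhibition than methyl.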